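The compounds below may be only part of what the source reports. "The series", "measured", "known", "first", "only" and "open" are said of these compounds alone.

Measured so far:
compound 1 `c1ccc(-c2cn3ccnc3c(-c3ccc4ncn(C5CCCCC5)c4c3)n2)cc1` gives 28.8%
compound 2 `c1ccc2c(-c3cn4ccnc4c(-c4ccc5ncn(C6CCCCC6)c5c4)n3)cccc2c1` gives 11.7%
compound 3 `Fc1ccc(-c2cn3ccnc3c(-c3ccc4ncn(C5CCCCC5)c4c3)n2)cc1` gives 3.97%

In a functional assay on SN12C cells (Homo sapiens) for inhibition, read by sulforhodamine B assay, with a stated time of 48 h, tested at 10 uM (a higher number here means more inhibition at the concentration tested (going by the name of the read-out), a lower number less inhibition), compound 2 holds the second highest of the three numbers; its nearest neighbour is compound 3, with a number 7.7 percentage points lower from compound 2 to compound 3 (within the scatter), while compound 1 sits higher, with a number 17.1 percentage points lower from compound 1 to compound 2 (beyond the scatter). The step to compound 4 `COc1ccccc1-c1cn2ccnc2c(-c2ccc3ncn(C4CCCCC4)c3c2)n1` is 2-methoxyphenyl in place of naphthalen-1-yl on an aromatic carbon. Within the data shown here, no measured pair matches this change directly. Among the measured compounds shown here, the steps that bear on it are a number 17.1 percentage points lower from compound 1 to compound 2 (beyond the scatter), where naphthalen-1-yl replaced phenyl, and a number 24.8 percentage points lower from compound 1 to compound 3 (beyond the scatter), where fluoro entered the phenyl ring; both lowered the read-out modestly. Compound 4 returns to one six-membered aromatic ring of carbon only but carries a methoxy, so for compound 4 no step beyond the scatter is expected, a number 3.3 percentage points higher from compound 2 to compound 4 (within the scatter). Compound 4 is therefore estimated at 15%, in the range 0% to 35%.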

Compound 4, a percentage reported as inhibition, at one concentration (the size of the read-out at that concentration, not a potency): 7.73%
For compound 4 the middle estimate is 7.3 percentage points above the measured one; the range from low to high includes it.
By their numbers in this assay, from the lowest: compounds 3, 4 and 2 (each within the scatter of the next); then compound 1.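

In this assay, 2-methoxyphenyl also falls short of plain phenyl at this aromatic carbon, with a number 21.1 percentage points lower from compound 1 to compound 4 (beyond the scatter) adding a third replacement that lowers the read-out beyond the scatter. It cannot be separated from the other two replacements, given a number 4 percentage points lower from compound 2 to compound 4 (within the scatter) and a number 3.8 percentage points higher from compound 3 to compound 4 (within the scatter), so the three compounds form one group here. Nothing available accounts for the loss from compound 1. 

On these data alone, whether any replacement at this carbon matches or exceeds compound 1 remains open. A phenyl carrying an amine or a carboxylic acid would test whether the loss extends beyond these three groups.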